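Phenylethynyl for phenylethenyl on a selenium-bearing amide series

A few compounds are considered here, and "the series" means these few. Any claim that something is new, unique, unknown or untested is made for them only; others in the source may bear on it.

Measured so far in a functional assay on A-431 cells (Homo sapiens) for cytotoxicity, read by MTT assay, with a stated time of 24 h; on this read-out lower numbers stand for stronger inhibition and higher numbers for weaker inhibition:
- compound 1, `COc1ccc(N(CC(=O)NCCC[Se]c2ccccc2)C(=O)c2ccccc2)cc1`: >= 100000 nM
- compound 2, `COc1ccc(N(CC(=O)NCCC[Se]c2ccccc2)C(=O)CNC(=O)OC(C)(C)C)cc1`: >= 100000 nM
- compound 3, `COc1ccc(N(CC(=O)NCCC[Se]c2ccccc2)C(=O)/C=C/c2ccccc2)cc1`: >= 100000 nM

Each of these three values is a limit of the assay rather than a measured number. Among the measured compounds shown here, compound 3 therefore stands at the same limit as the other two, and no compound can be placed above or below another. The three steps among them, a step that the two limits leave unreadable from compound 1 to compound 2, a step that the two limits leave unreadable from compound 1 to compound 3 and a step that the two limits leave unreadable from compound 2 to compound 3, are unreadable for the same reason: both ends of each step sit at the limit, as summarised by the limit of >= 100000 nM in this assay, at which 3 of the 3 values shown sit.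

The next compound, compound 4, `COc1ccc(N(CC(=O)NCCC[Se]c2ccccc2)C(=O)C#Cc2ccccc2)cc1`, differs from compound 3 only in the group attached to the carbonyl carbon: 2-phenylethynyl in place of 2-phenylethenyl on a carbonyl carbon. The measured steps, all of which swap one group on this same carbonyl carbon, give no readable size in any direction, so they offer no reason to expect a change beyond the scatter here either.

Compound 4 is therefore expected to sit at the same limit, with an estimated step of a number no higher from compound 3 to compound 4 (the limit leaves the size open). The estimate for compound 4 in this assay is 100000 nM, within a range from 20000 nM to 500000 nM.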

Compound 4, half-maximal inhibitory concentration: >= 100000 nM
Compound 4 was reported as a limit; the forecaster's own chance of this, stated with the estimate: 75%; the middle value sits exactly at the limit.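

In this assay compound 4 gives >= 100000 nM as a limit, not a number. No step from compound 1, compound 2 or compound 3 to compound 4 can be read, because both ends of each step sit at a limit: the limit of >= 100000 nM in this assay, at which 4 of the 4 values shown sit.

The compounds shown leave open whether any group on this carbonyl carbon would give a measured number rather than a limit in this assay at all.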